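Anilide variation on the shared core: hydroxy to fluoro swap

A few compounds are considered here, and "the series" means these few. Any claim that something is new, unique, unknown or untested is made for them only; others in the source may bear on it.

Three members of the series have been measured in a functional assay on NCI-H460 cells (Homo sapiens) for inhibition, read by CCK-8 assay, with a stated time of 72 h, tested at 10 uM; a lower number here means less inhibition of growth, a higher number more inhibition of growth at the concentration tested. Compound 1 `CN(C)C(=O)c1cc2cnc(Nc3ccc(NC(=O)C4(C(=O)Nc5cccc(O)c5)CC4)cc3)nc2n1C1CCCC1` gives 94.9% and holds the second of the three numbers, though both steps from it lie within the scatter: a number 3 percentage points lower from compound 1 to compound 2 (within the scatter) to compound 2 `CN(C)C(=O)c1cc2cnc(Nc3ccc(NC(=O)C4(C(=O)Nc5ccc(Cl)c(C(F)(F)F)c5)CC4)cc3)nc2n1C1CCCC1` with 91.9%, and a number 3.9 percentage points higher from compound 1 to compound 3 (within the scatter) to compound 3 `CN(C)C(=O)c1cc2cnc(Nc3ccc(NC(=O)C4(C(=O)Nc5cccc(F)c5)CC4)cc3)nc2n1C1CCCC1` with 98.8%. Compound 4 `CN(C)C(=O)c1cc2cnc(Nc3ccc(NC(=O)C4(C(=O)Nc5ccc(F)cc5)CC4)cc3)nc2n1C1CCCC1` has not been measured; it differs from compound 1 by 4-fluorophenyl in place of 3-hydroxyphenyl on an amide-type nitrogen. The step bearing most on it is a number 3.9 percentage points higher from compound 1 to compound 3 (within the scatter), also a fluoro for hydroxy change, and a number 3 percentage points lower from compound 1 to compound 2 (within the scatter) and a number 6.9 percentage points higher from compound 2 to compound 3 (within the scatter) show the same flat picture. No step beyond the scatter is therefore expected, so a number 1.1 percentage points higher from compound 1 to compound 4 (within the scatter) is the estimated change. Compound 4 is expected to give 96%, within 87% to 100%.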

Compound 4, percent growth inhibition at one concentration: 102%
Estimate against measurement, compound 4: 6 percentage points below, and the stated range ends below it.
By their numbers in this assay, from the lowest: compounds 2, 1, 3 and 4 (each within the scatter of the next, the first and the last beyond it).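

In this assay, 4-fluorophenyl in place of 3-fluorophenyl stays within the scatter (a number 3.2 percentage points higher from compound 3 to compound 4 (within the scatter)), as does 4-fluorophenyl in place of 3-hydroxyphenyl (a number 7.1 percentage points higher from compound 1 to compound 4 (within the scatter)). Within the data shown here, only 4-fluorophenyl in place of 4-chloro-3-(trifluoromethyl)phenyl gives a modest step beyond the scatter (a number 10.1 percentage points higher from compound 2 to compound 4 (beyond the scatter)), the first pair to separate. Nothing measured accounts for this step.

As far as these compounds go, with a single tested concentration, any order among compounds 1, 3 and 4 stays open. Also open, from the compounds shown here alone, is how an aminophenyl, a carboxyphenyl or an open alkyl chain on the amide-type nitrogen would read.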